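A few compounds are considered here, and "the series" means these few. Any claim that something is new, unique, unknown or untested is made for them only; others in the source may bear on it.

Compound 3 `CN1CCN(c2nc(-n3ccc4ccccc43)c3ccccc3n2)CC1` gives 6 ug/mL in a functional assay on MCF7 cells (Homo sapiens) for antiproliferative activity, read by MTT assay (on this read-out higher numbers stand for weaker inhibition and lower numbers for stronger inhibition), the lowest of the three numbers measured. Compound 1 `c1ccc2c(c1)ccn2-c1nc(N2CCNCC2)nc2ccccc12` gives 14.1 ug/mL in this assay, and compound 2 `c1ccc(N2CCN(c3nc(-n4ccc5ccccc54)c4ccccc4n3)CC2)cc1` gives 50 ug/mL. The three differ only at the amine nitrogen of the ring: a 2.4-fold lower number from compound 1 to compound 3 (0.37 log units; beyond the scatter), a 3.5-fold higher number from compound 1 to compound 2 (0.55 log units; beyond the scatter), and an 8.3-fold lower number from compound 2 to compound 3 (0.92 log units; beyond the scatter). Compound 4 `c1ccc2c(c1)ccn2-c1nc(N2CCCCC2)nc2ccccc12` is reached from compound 3 by a change of another kind: piperidin-1-yl in place of 4-methylpiperazin-1-yl on an aromatic carbon. Here the methyl-bearing nitrogen is not exchanged for another substituent but removed with the ring becoming piperidin-1-yl. Among the compounds with values here, none of the measured steps covers this; they show only that what sits on that nitrogen shifts the number by modest amounts, with hydrogen and phenyl both giving higher numbers than methyl. On that basis a modest weakening is expected for compound 4, with wide uncertainty, so that compound 4 is estimated at 12 ug/mL in this assay, between 4 ug/mL and 40 ug/mL, corresponding to an expected step of a 2.0-fold higher number from compound 3 to compound 4 (0.30 log units; within the scatter).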

Compound 4, half-maximal inhibitory concentration: 50 ug/mL
For compound 4 the middle estimate is 4.2-fold (0.62 log units) below the measured one; the measured number lies above the stated range.
By their numbers in this assay, from the lowest: compound 3; then compound 1; then compounds 2 and 4 (each within the scatter of the next).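

In this assay, the second ring nitrogen itself proves to matter, not only what it carries: removing it gives an 8.3-fold higher number from compound 3 to compound 4 (0.92 log units; beyond the scatter), and the same change without the methyl gives a 3.5-fold higher number from compound 1 to compound 4 (0.55 log units; beyond the scatter). Presence of that nitrogen is not enough, however, since compound 2 keeps it and gives 50 ug/mL, the same printed number as compound 4. Nothing available explains these shifts.

The compounds shown leave open whether an oxygen in that ring position, as in morpholin-4-yl, would behave like the nitrogen or like the carbon of piperidin-1-yl. They also leave open whether an ethyl or a longer chain on the nitrogen would stay close to the methyl of compound 3 or move towards the phenyl of compound 2.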